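The source may hold more compounds than are shown below. What is called first, only, known or untested is meant among the compounds shown, and "the series" means these compounds.

In an assay on cell membranes for binding affinity to Adrenergic receptor alpha-1 (Rattus norvegicus), read by radioligand binding (on this read-out lower numbers stand for stronger inhibition and higher numbers for weaker inhibition), compound 1 `COc1ccccc1N1CCN(CCn2ncc(N3CCN(C(=O)c4ccco4)CC3)c(Cl)c2=O)CC1` gives 33 nM, and compound 2 `O=C(c1ccco1)N1CCN(c2cnn(CCN3CCN(c4ccccc4Cl)CC3)c(=O)c2Cl)CC1` gives 3.9 nM. The change between them, (chloro in place of methoxy on an aromatic carbon), made the step of an 8.5-fold lower number from compound 1 to compound 2 (0.93 log units; beyond the scatter). Compound 3 `COc1ccccc1N1CCN(CCCCCCn2ncc(N3CCN(C(=O)c4ccco4)CC3)c(Cl)c2=O)CC1` gives 4.1 nM in this assay; how the core of compound 3 differs from the core of compound 1 is not broken down here. Compound 4 `O=C(c1ccco1)N1CCN(c2cnn(CCCCCCN3CCN(c4ccccc4Cl)CC3)c(=O)c2Cl)CC1` has not yet been measured in this assay. It differs from compound 3 by chloro in place of methoxy on an aromatic carbon, the same change as that from compound 1 to compound 2, made at the same kind of place. From compound 3 to compound 4 a step of a 2.7-fold lower number from compound 3 to compound 4 (0.44 log units; beyond the scatter) is expected, resting on the earlier step of an 8.5-fold lower number from compound 1 to compound 2 (0.93 log units; beyond the scatter), though compound 3 already gives 4.1 nM. Compound 4 is therefore estimated at 1.5 nM, expected to lie between 0.5 nM and 5 nM.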

Compound 4, inhibition constant: 5.7 nM
Estimate against measurement, compound 4: 3.8-fold (0.58 log units) below; the measured number lies above the stated range.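

In this assay, putting 2-chlorophenyl in place of 2-methoxyphenyl gave a 1.4-fold higher number from compound 3 to compound 4 (0.14 log units; within the scatter), so the large step seen on the core of compound 1 did not recur on the core of compound 3. The two steps differ: the same change on two cores in this assay, an 8.5-fold lower number (0.93 log units; beyond the scatter) from compound 1 to compound 2 and a 1.4-fold higher number (0.14 log units; within the scatter) from compound 3 to compound 4, 12-fold (1.07 log units) apart, beyond the scatter of two such steps. This shows that the size of this step does not carry from one of these cores to the other, but two pairs do not show what sets the difference or how the change would read on any further core.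

The compounds shown leave open how a fluoro or methyl group on the same aromatic carbon would read on these two cores. They also leave open how the change would read with a shorter or longer chain.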